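Working notes: from compound 2 to compound 3

The source may report more compounds than this note shows. Statements on the series, on what has been measured and on what is new or still open speak of the compounds shown alone.

Values so far in a functional assay on the whole organism with Mus musculus as the target; on this read-out lower numbers stand for an effect already at smaller amounts and higher numbers for an effect only at larger amounts of compound
- compound 1 `CN(CC(N)=O)Cc1ccc(OCc2cccc(Cl)c2)cc1` gives 114 mg/kg
- compound 2 `C[C@@H](NCc1ccc(OCc2ccccc2)cc1)C(N)=O` gives 23.8 mg/kg

Compound 2 at 23.8 mg/kg holds the lower of the two numbers, with compound 1 beyond the scatter above it. The next compound is compound 3 `CNC(=O)[C@H](C)NCc1ccc(OCc2ccccc2)cc1`, which differs from compound 2 as follows: 1-(methylcarbamoyl)ethyl in place of 1-carbamoylethyl on an amine nitrogen. In words, 1-(methylcarbamoyl)ethyl stands in place of 1-carbamoylethyl on an amine nitrogen. Going by the values given here, no measured pair shows this change, so no step beyond the scatter is expected in this assay, with a slightly higher number somewhat more likely. The estimated step runs a 1.3-fold higher number from compound 2 to compound 3 (0.10 log units; within the scatter). Compound 3 is estimated at 30 mg/kg, with an expected range from 12 mg/kg to 80 mg/kg.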

Compound 3, dose for half-maximal effect: 8.4 mg/kg
For compound 3 the middle estimate is 3.6-fold (0.55 log units) above the measured one, outside the stated range (below it).
By their numbers in this assay, from the lowest: compound 3; then compound 2; then compound 1.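

In this assay, going by these compounds alone, 1-(methylcarbamoyl)ethyl in place of 1-carbamoylethyl on an amine nitrogen gives a 2.8-fold lower number from compound 2 to compound 3 (0.45 log units; beyond the scatter), the first single-place step. This position therefore accepts methyl on the amide nitrogen without loss, and the step is beyond the scatter. No evidence at hand accounts for the step.

Open, going by these compounds, is whether an ethyl amide or a dimethyl amide at this position would extend the step or reverse it. On these data alone, a carboxylic acid in place of the amide also remains open.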